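A few compounds are considered here, and "the series" means these few. Any claim that something is new, unique, unknown or untested is made for them only; others in the source may bear on it.

Measured compounds:
- compound 1 `Oc1ccccc1/C=N/Nc1ncccn1`: 84200 nM
- compound 2 `Oc1cccc(/C=N/Nc2ncccn2)c1O`: > 150000 nM (a limit of the assay)

Going by the values given here, in an ADME assay on cells (Peritoneal macrophage, Mus musculus, strain BALB/c) for cytotoxicity, with a stated time of 72 h (on this read-out lower numbers stand for higher toxicity in this test and higher numbers for lower toxicity in this test), compound 1 gives 84200 nM, the only exact number so far. The entry for compound 2 is only a limit. Compound 3 `Oc1ccc(O)c(/C=N/Nc2ncccn2)c1` differs from compound 1 by hydroxy in place of hydrogen on an aromatic carbon. One measured step of the same kind, hydroxy in place of hydrogen on an aromatic carbon, bears on this: an at least 1.7-fold higher number from compound 1 to compound 2 (0.25 log units; that floor lies within the scatter). No shift beyond the scatter is therefore expected in this assay. The estimated step is a 1.2-fold higher number from compound 1 to compound 3 (0.07 log units; within the scatter). The expected value for compound 3 is 100000 nM, with an estimated range of 40000 nM to 200000 nM.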

Compound 3, half-maximal cytotoxic concentration: 89400 nM
Estimate against measurement, compound 3: 1.1-fold (0.05 log units) above; the range from low to high includes it.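

With the second hydroxy para to a hydroxy group and meta to a group of 9 heavy atoms, this assay gives a 1.1-fold higher number from compound 1 to compound 3 (0.03 log units; within the scatter) as an exact step for this change. Going by these compounds alone, no shift can be read from it at this position, and this is the first exact size for hydroxy in place of hydrogen on this core. The entry for compound 2 is a limit, so its own hydroxy step has no exact size: the limit of > 150000 nM in this assay, at which 1 of the 3 values shown sits.

The compounds shown leave open whether an amine or a carboxylic acid on this same aromatic carbon would give a shift beyond the scatter in this assay as well. They also leave open what a methoxy group would do there.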